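The source may hold more compounds than are shown below. What is called first, only, known or untested is meant among the compounds shown, and "the series" means these compounds.

Compound 1 `C[C@@H]1CN(c2nc(-c3cnn(C)c3)ncc2C#N)CCN1C(=O)C1CCC1`: < 16 mL/min/kg
Compound 2 `C[C@@H]1CN(c2ncc(C#N)c(-c3cnn(C)c3)n2)CCN1C(=O)C1CC1`: < 16 mL/min/kg

In an ADME assay on microsomes from liver (Homo sapiens) for pharmacokinetics (on this read-out higher numbers stand for fast clearance and lower numbers for slow clearance), compound 1 gives < 16 mL/min/kg, which is a limit of the assay and not a number. Compound 2 gives < 16 mL/min/kg, which is also a limit. Both compounds therefore stand at the limit of < 16 mL/min/kg in this assay, at which 2 of the 2 values shown sit, and the series has no exact value yet.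

Compound 3 `CCC(=O)N1CCN(c2nc(-c3cnn(C)c3)ncc2C#N)C[C@H]1C` is still to be measured. It carries ethyl in place of cyclobutyl on a carbonyl carbon, the other neighbour of that carbon being an amide-type nitrogen in a ring (ethyl in place of cyclobutyl on a carbonyl carbon). Among the compounds with values here, no measured step shows what such a change does, so no shift beyond the usual scatter is expected. The expected step is a step that the limit leaves unreadable from compound 1 to compound 3. Compound 3 may well also be reported only as a limit. For compound 3 the estimated value is 11 mL/min/kg, with an expected range from 6 mL/min/kg to 20 mL/min/kg.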

Compound 3, clearance: < 16 mL/min/kg
Compound 3: no number, only a limit; the forecaster's own chance of this, stated with the estimate: 75%; the middle value is on the limit's open side.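

Compound 3, like compound 1, gives a limit and not a number in this assay, so no step can be read for ethyl in place of cyclobutyl. What stays open is how far the clearance of each compound lies from the shared limit: the limit of < 16 mL/min/kg in this assay, at which 3 of the 3 values shown sit.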